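Acetamido to amino across two linker lengths

This account rests on a few compounds, and the source may have more. Where it says the series, first, only, none or still open, it means among the compounds named here.

Compound 1 `COc1cc2cc(NC(C)=O)c(=O)oc2cc1OCCOc1no[n+]([O-])c1S(=O)(=O)c1ccccc1` and compound 2 `COc1cc2cc(NC(C)=O)c(=O)oc2cc1OCCCCOc1no[n+]([O-])c1S(=O)(=O)c1ccccc1` carry the acetyl group on the ring nitrogen; compound 3 `COc1cc2cc(N)c(=O)oc2cc1OCCOc1no[n+]([O-])c1S(=O)(=O)c1ccccc1` and the still unmeasured compound 4 `COc1cc2cc(N)c(=O)oc2cc1OCCCCOc1no[n+]([O-])c1S(=O)(=O)c1ccccc1` carry the free amino group there. The difference between the cores of compound 1 and compound 2 is not broken down here. In a functional assay on A549 cells (Homo sapiens) for inhibition, read by MTT assay, with a stated time of 48 h (on this read-out lower numbers stand for stronger inhibition and higher numbers for weaker inhibition), compound 1 gives 8790 nM, compound 2 gives 7190 nM and compound 3 gives 5910 nM. Compound 3 differs from compound 1 by hydrogen in place of acetyl on a nitrogen on an aromatic ring, a change that produced a 1.5-fold lower number from compound 1 to compound 3 (0.17 log units; within the scatter). Compound 4 differs from compound 2 by hydrogen in place of acetyl on a nitrogen on an aromatic ring, the same change at the same place. Among the measured compounds shown here, for compound 4 a step of a 1.4-fold lower number from compound 2 to compound 4 (0.14 log units; within the scatter) is expected in this assay, resting only on the one earlier instance a 1.5-fold lower number from compound 1 to compound 3 (0.17 log units; within the scatter), so a small shift is expected. Compound 4 is estimated at 5200 nM in this assay, with a likely range from 2500 nM to 10500 nM.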

Compound 4, half-maximal inhibitory concentration: 5030 nM
Compound 4: middle estimate off by 1.0-fold (0.01 log units), on the high side, within the range that was stated.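

In this assay the change from acetamido to amino gives a 1.4-fold lower number from compound 2 to compound 4 (0.16 log units; within the scatter) and reads alike on the two cores shown: the same change on two cores in this assay, a 1.5-fold lower number (0.17 log units; within the scatter) from compound 1 to compound 3 and a 1.4-fold lower number (0.16 log units; within the scatter) from compound 2 to compound 4, 1.0-fold (0.02 log units) apart, within the scatter of two such steps. Both steps lie within the scatter, so this shows a change that carries between these two cores without a detectable difference in step size, but it does not show that the amino group truly alters the read-out. Two cores also cannot establish how the change behaves on any other core in the series.

Open, as far as these compounds go, is whether a benzoyl group on that nitrogen would give a step beyond the scatter. Also open, from the compounds shown here alone, is whether the step would hold with a longer chain in the linker.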